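This account rests on a few compounds, and the source may have more. Where it says the series, first, only, none or still open, it means among the compounds named here.

Measured in a functional assay (blood) for inhibition, with Homo sapiens as the target; on this read-out higher numbers stand for weaker inhibition and lower numbers for stronger inhibition:
- compound 1 `CC(O)c1cc(-c2ccccc2)c2ccc(OCc3cccc(C4(O)CCOCC4)c3)cc2c1`: 675 nM
- compound 2 `CC(=O)c1cc(-c2ccccc2)c2ccc(OCc3cccc(C4(O)CCOCC4)c3)cc2c1`: 90 nM

Not yet measured: compound 3 `N#Cc1cc(-c2ccccc2)c2ccc(OCc3cccc(C4(O)CCOCC4)c3)cc2c1`.

Among the compounds with values here, compound 2, at 90 nM, has the lower of the two numbers so far, which makes it the stronger inhibitor of the pair. Compound 3 has cyano in place of acetyl on an aromatic carbon. Within the data shown here, only one measured step bears on this change: a 7.5-fold lower number from compound 1 to compound 2 (0.88 log units; beyond the scatter), which came with acetyl in place of 1-hydroxyethyl at that same carbon. That step shows that this position can matter, but cyano itself has not been tested there, so the direction remains uncertain. A small rise, perhaps none beyond the scatter, is expected, and a much smaller change than the measured step. The expected step is a 1.6-fold higher number from compound 2 to compound 3 (0.19 log units; within the scatter). For compound 3 the estimated value is 140 nM, with an expected range from 40 nM to 450 nM.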

Compound 3, half-maximal inhibitory concentration: 100 nM
Estimate against measurement, compound 3: 1.4-fold (0.15 log units) above; measured number inside the range.
By their numbers in this assay, from the lowest: compounds 2 and 3 (each within the scatter of the next); then compound 1.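

In this assay, cyano and acetyl at this aromatic carbon cannot be told apart (a 1.1-fold higher number from compound 2 to compound 3 (0.05 log units; within the scatter)), so a carbonyl as such is not required there. Compound 1 now stands apart from two different groups rather than one (a 6.8-fold lower number from compound 1 to compound 3 (0.83 log units; beyond the scatter)), and neither of those groups carries the hydroxyl found in compound 1. No measurement offered here explains why cyano and acetyl match.

The compounds shown leave open how far this match extends: a primary amide, a carboxylic acid or a plain methyl group at this carbon could fall with compound 2 and compound 3, or with compound 1. They also leave open whether the hydroxyl alone sets compound 1 apart, a question that a methoxy group at the same carbon would begin to test.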